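Replacing the 2-amino-3,5-dibromophenyl group of compound 3

The source may hold more compounds than are shown below. What is called first, only, known or untested is meant among the compounds shown, and "the series" means these compounds.

Measured in a functional assay on DU-145 cells (Homo sapiens) for inhibition, read by trypan blue exclusion, with a stated time of 96 h; a lower number here means a stronger inhibitor of growth, a higher number a weaker inhibitor of growth:
compound 1 `COc1cc(/C=C(/Sc2ccc(Br)cc2)C(=O)c2ccc(Br)cc2)ccc1O`: 1000 nM
compound 2 `COc1ccc(/C=C(/Sc2ccc(Br)cc2)C(=O)c2ccc(Br)cc2)cc1`: 25000 nM
compound 3 `Nc1c(Br)cc(Br)cc1/C=C(/Sc1ccc(Br)cc1)C(=O)c1ccc(Br)cc1`: > 100000 nM (a limit)

Compound 3 stands at > 100000 nM, which is a limit of the assay and not a number. Compound 4 `COc1ccc(/C=C(/Sc2ccc(Br)cc2)C(=O)c2ccc(Br)cc2)c(F)c1` has 2-fluoro-4-methoxyphenyl in place of 2-amino-3,5-dibromophenyl on a double-bonded chain carbon bound to a double-bonded chain carbon. Two measured steps end at the same group that compound 4 gives up: an at least 100-fold higher number from compound 1 to compound 3 (2.00 log units; beyond the scatter) and an at least 4.0-fold higher number from compound 2 to compound 3 (0.60 log units; beyond the scatter). The closer guide is the second, whose starting group, 4-methoxyphenyl, resembles the entering one. A step towards a stronger inhibitor of growth is therefore expected in this assay, an at least 5.0-fold lower number from compound 3 to compound 4 (0.69 log units; beyond the scatter). Compound 4 is estimated at 20000 nM, within a range of 6000 nM to 70000 nM.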

Compound 4, concentration for 50% growth inhibition: 20000 nM
The estimate for compound 4 equals the measured number at the digits printed, and the stated range covers the measured number.
By their numbers in this assay, from the lowest: compound 1; then compounds 4 and 2 (each within the scatter of the next). At a limit, above all of these: compound 3.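

In this assay, fluoro in place of hydrogen on an aromatic carbon leaves the two compounds within the scatter: a 1.3-fold lower number from compound 2 to compound 4 (0.10 log units; within the scatter). The 2-fluoro-4-methoxyphenyl group still falls well short of the 4-hydroxy-3-methoxyphenyl group, a 20-fold higher number from compound 1 to compound 4 (1.30 log units; beyond the scatter), though it reads better than the 2-amino-3,5-dibromophenyl group, an at least 5.0-fold lower number from compound 3 to compound 4 (0.69 log units; beyond the scatter). Compound 3 stands at a limit, so that last step gives only a bound: the limit of > 100000 nM in this assay, at which 1 of the 4 values shown sits.

The compounds shown leave open whether chloro or an amine in place of that fluoro would read differently. They also leave open whether a hydroxy group added to the 2-fluoro-4-methoxyphenyl group would bring the number towards that of compound 1.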